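This account rests on a few compounds, and the source may have more. Where it says the series, first, only, none or still open, it means among the compounds named here.

Measured so far:
compound 1 `O=C1CCCN1c1cnc(NCc2c(F)ccc3c2CCO3)c2cn[nH]c(=O)c12`: 23 mL.min-1.g-1
compound 2 `O=C(Nc1cnc(NCc2c(F)ccc3c2CCO3)n2cnnc12)c1ccccc1`: 10 mL.min-1.g-1
compound 3 `Cc1ncccc1-c1cnc(NCc2c(F)ccc3c2CCO3)n2c(=O)[nH]nc12`: 36 mL.min-1.g-1

All three were tested in an ADME assay on microsomes from liver (Homo sapiens) for metabolic stability, read by LC-MS, using NADPH, with stated times of 5 min and 30 min, tested at 1 uM; a lower number here means slower removal, a higher number faster removal of the compound. Compound 2 gives the lowest of the three numbers: compound 1 sits higher, and compound 3 sits higher still, each gap lying beyond the usual scatter of this kind of measurement. Compound 4 `CN(C(=O)c1ccccc1)c1cnc(NCc2c(F)ccc3c2CCO3)n2cnnc12` has not yet been measured. It differs from compound 2 in one place, (methyl in place of hydrogen on an amide-type nitrogen). Within the data shown here, no pair among the measured compounds shows this same change, so there is no earlier step to lean on. The change is expected to bring a small rise, a 1.5-fold higher number from compound 2 to compound 4 (0.18 log units; within the scatter), perhaps no larger than the scatter. Compound 4 is estimated at 15 mL.min-1.g-1, with a likely range from 6 mL.min-1.g-1 to 40 mL.min-1.g-1.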

Compound 4, intrinsic clearance in microsomes: > 300 mL.min-1.g-1
Compound 4: no number, only a limit (the forecaster's own chance of this, stated with the estimate: 5%); middle value at least 20-fold (1.30 log units) from the limit.
By their numbers in this assay, from the lowest: compound 2; then compounds 1 and 3 (each within the scatter of the next). At a limit, above all of these: compound 4.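

In this assay, methyl in place of hydrogen on an amide-type nitrogen gives an at least 30-fold higher number from compound 2 to compound 4 (1.47 log units; beyond the scatter), the first step shown between two measured compounds that differ in one place. This nitrogen is therefore a place where adding 1 heavy atom can move the reading far beyond the scatter. Compound 4 stands at a limit of the assay, not at a number: the limit of > 300 mL.min-1.g-1 in this assay, at which 1 of the 4 values shown sits.

The compounds shown leave open whether an ethyl group or a longer chain on this nitrogen would behave like methyl. They also leave open whether the same change would act alike with acetyl in place of benzoyl.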